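Shortening the fatty acyl chain and cell toxicity

The source may hold more compounds than are shown below. What is called first, only, known or untested is meant among the compounds shown, and "the series" means these compounds.

Compound 3 `CCCCCCCCCCCCCCCC(=O)Nc1nnc(S[C@@H]2O[C@H](COC(C)=O)[C@H](OC(C)=O)[C@H](OC(C)=O)[C@H]2OC(C)=O)s1` gives 90400 nM in an ADME assay on CHO-K1 cells (Cricetulus griseus) for cytotoxicity, read by MTT assay, with a stated time of 24 h (on this read-out higher numbers stand for weaker inhibition and lower numbers for stronger inhibition), the highest of the three numbers and therefore the weakest inhibition among them. For comparison, compound 1 `CCCCCCCCCCCCCCCCCC(=O)Nc1nnc(S[C@@H]2O[C@H](COC(C)=O)[C@H](OC(C)=O)[C@H](OC(C)=O)[C@H]2OC(C)=O)s1` gives 44700 nM and compound 2 `CCCCCCCC/C=C\CCCCCCCC(=O)Nc1nnc(S[C@@H]2O[C@H](COC(C)=O)[C@H](OC(C)=O)[C@H](OC(C)=O)[C@H]2OC(C)=O)s1` gives 26300 nM; the steps towards compound 3 were a 2.0-fold higher number from compound 1 to compound 3 (0.31 log units; beyond the scatter) and a 3.4-fold higher number from compound 2 to compound 3 (0.54 log units; beyond the scatter). Compound 4 `CCCCCC(=O)Nc1nnc(S[C@@H]2O[C@H](COC(C)=O)[C@H](OC(C)=O)[C@H](OC(C)=O)[C@H]2OC(C)=O)s1` differs from compound 3 in one place: hydrogen in place of decyl on a saturated chain carbon, five bonds along the chain from a carbonyl carbon. Among the compounds with values here, the only measured step that bears on this is a smaller shortening of the same chain, a 2.0-fold higher number from compound 1 to compound 3 (0.31 log units; beyond the scatter), which moved the number upward beyond the scatter. A much larger shortening is expected to move it further in the same direction, so the estimate for compound 4 is 200000 nM, ranging from 80000 nM to 600000 nM, an expected step of a 2.2-fold higher number from compound 3 to compound 4 (0.34 log units; beyond the scatter).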

Compound 4, half-maximal inhibitory concentration: 24400 nM
Estimate against measurement, compound 4: 8.2-fold (0.91 log units) above; the whole stated range lies above it.
By their numbers in this assay, from the lowest: compounds 4, 2 and 1 (each within the scatter of the next); then compound 3.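

Removing the decyl group five bonds along the chain from a carbonyl carbon does not continue the upward move of the smaller shortening: in this assay the step is the opposite one (a 3.7-fold lower number from compound 3 to compound 4 (0.57 log units; beyond the scatter)). The number does not follow chain length across these compounds, as the steps (a 1.8-fold lower number from compound 1 to compound 4 (0.26 log units; within the scatter)) and (a 1.1-fold lower number from compound 2 to compound 4 (0.03 log units; within the scatter)) leave compound 4 within the scatter of both long-chain compounds, and compound 3 alone stands apart. Nothing measured here explains this.

Going by these compounds, what a still shorter chain would give, or a chain carrying an amine or a carboxylic acid, stays open.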